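Swapping a benzyl for a methoxyphenyl on a thiosemicarbazone

The source may hold more compounds than are shown below. What is called first, only, known or untested is meant among the compounds shown, and "the series" means these compounds.

Three quinoline-based thiosemicarbazones have been tested in a functional assay on SGC-7901 cells (Homo sapiens) for antiproliferative activity, read by sulforhodamine B assay, with a stated time of 72 h; a lower number here means a stronger inhibitor, a higher number a weaker inhibitor. Compound 1, with structure `CN(C)C(=S)N/N=C/c1ccc2ccccc2n1`, gives 30 nM in this assay. Compound 2, with structure `COc1ccc(C)cc1NC(=S)N/N=C/c1ccc2ccccc2n1`, reaches only the limit of this assay, > 100000 nM, and that is a limit rather than a number. Compound 3, with structure `S=C(NCc1ccccc1)N/N=C/c1ccc2ccccc2n1`, gives 53700 nM in this assay, which is the higher of the two real numbers; the gap to compound 1 lies well beyond the usual scatter.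

Compound 4, with structure `COc1cccc(NC(=S)N/N=C/c2ccc3ccccc3n2)c1`, is still to be measured. It differs from compound 3 by a single change: 3-methoxyphenyl in place of benzyl on an amide-type nitrogen. Among the measured compounds, the nearest relative of compound 4 in kind is compound 2, which reached only a limit, while the benzyl analogue compound 3 gave a number near the upper end of the range. The step from compound 3 to compound 4 is therefore expected to be a modest rise, a 1.7-fold higher number from compound 3 to compound 4 (0.22 log units; within the scatter), toward weaker inhibition. In this assay compound 4 is expected to give about 90000 nM, within a range of 20000 nM to 300000 nM, with a real chance that only a limit is reported.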

Compound 4, half-maximal inhibitory concentration: 79400 nM
The estimate for compound 4 lay 1.1-fold (0.05 log units) above the measured number, within the range that was stated.
By their numbers in this assay, from the lowest: compound 1; then compounds 3 and 4 (each within the scatter of the next). At a limit, above all of these: compound 2.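

In this assay, placing 3-methoxyphenyl in place of benzyl on the amide-type nitrogen gives a 1.5-fold higher number from compound 3 to compound 4 (0.17 log units; within the scatter). Going by these compounds alone, this is the first direct one-place comparison at this nitrogen, and it shows that these two ring-bearing groups cannot be told apart here. The oxygen and the hydrogen-bond acceptor that enter with 3-methoxyphenyl bring no measurable gain in this one pair, and both compounds remain far from compound 1, which gives 30 nM.

The compounds shown leave open whether a piperidine ring, a carboxylic acid or a longer alkyl chain at this position would give a number nearer to that of compound 1. Compound 2 also offers no number for comparison, only a limit: the limit of > 100000 nM in this assay, at which 1 of the 4 values shown sits.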